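Chain variation on the shared core: expectation for compound 4

The source may hold more compounds than are shown below. What is called first, only, known or untested is meant among the compounds shown, and "the series" means these compounds.

The shared core is that of compound 1 `CCOc1ccc2c(=O)c(-c3ccc(O)cc3)coc2c1`, which in an assay on isolated protein (Cricetulus griseus) for inhibition of Monoamine oxidase (Homo sapiens) (a lower number here means a stronger inhibitor, a higher number a weaker inhibitor), gives 300 nM. Compound 2 `O=c1c(-c2ccc(O)cc2)coc2cc(OCCC3OCCCO3)ccc12` gives 7000 nM in this assay, and compound 3 `O=c1c(-c2ccc(O)cc2)coc2cc(OCC(O)CO)ccc12` gives 1700 nM. Compound 3 thus stands second highest of the three numbers, nearer to compound 2 and further from compound 1, both gaps beyond the scatter.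

Compound 4 `O=C(O)CCCCCCOc1ccc2c(=O)c(-c3ccc(O)cc3)coc2c1` differs from compound 3 by 5-carboxypentyl in place of 1,2-dihydroxyethyl on a saturated chain carbon bound to an oxygen on an aromatic ring. The measured steps bearing on it are those that alter the chain at this position: a 5.7-fold higher number from compound 1 to compound 3 (0.75 log units; beyond the scatter) and a 23-fold higher number from compound 1 to compound 2 (1.37 log units; beyond the scatter), while a 4.1-fold lower number from compound 2 to compound 3 (0.61 log units; beyond the scatter). Every departure from the methyl of compound 1 raised the number in this assay, the larger group raising it more. The chain entering in compound 4 is longer than either replacement measured so far, so a higher number in this assay is expected for compound 4, of a size estimated as a 3.5-fold higher number from compound 3 to compound 4 (0.55 log units; beyond the scatter). Within the data shown here, no measured step shows how a carboxylic acid at the chain end behaves, which widens the range. For compound 4 the estimate in this assay is 6000 nM, with a range from 2000 nM to 20000 nM.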

Compound 4, half-maximal inhibitory concentration: 2100 nM
Compound 4: middle estimate off by 2.9-fold (0.46 log units), on the high side, and the stated range covers the measured number.
By their numbers in this assay, from the lowest: compound 1; then compounds 3 and 4 (each within the scatter of the next); then compound 2.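

In this assay, at the saturated chain carbon bound to an oxygen on an aromatic ring, 5-carboxypentyl and 1,2-dihydroxyethyl cannot be told apart, the step being a 1.2-fold higher number from compound 3 to compound 4 (0.09 log units; within the scatter), so compound 4 goes against the earlier reading that the larger group gives the higher number. Group size alone therefore no longer orders the series, and the open chain of compound 4 stands clear of the ring-bearing chain of compound 2, with a 3.3-fold lower number from compound 2 to compound 4 (0.52 log units; beyond the scatter), leaving compound 2 with the highest number of the four. Compound 1 keeps the lowest number, with a 7.0-fold higher number from compound 1 to compound 4 (0.85 log units; beyond the scatter), so neither the terminal carboxylic acid chain nor the diol chain matches the small group at this position.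

No measurement at hand accounts for any of these steps. Still open, on these data alone, is whether the carboxylic acid itself contributes to the number of compound 4, which could be tested by comparing it with a plain hexyl chain, a methyl ester or an amine at the same chain end.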